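The source may report more compounds than this note shows. Statements on the series, on what has been measured and on what is new or still open speak of the compounds shown alone.

Two catechol esters have been run in an ADME assay on HFF-1 cells (Homo sapiens) for cytotoxicity, read by MTT assay, with a stated time of 24 h (on this read-out higher numbers stand for lower toxicity in this test and lower numbers for higher toxicity in this test), so far. In this assay compound 1 `CCCCOC(=O)CCc1ccc(O)c(O)c1` gives 100 ug/mL. In this assay compound 2 `CC(=O)OCCc1ccc(O)c(O)c1` gives 50 ug/mL. Going by the values given here, on the numbers so far compound 2 stands at the bottom of the pair, but the distance to compound 1 lies within the scatter, so the two are not separated by this test.

The next member is compound 3 `CCC(=O)OCCc1ccc(O)c(O)c1`. It departs from compound 2 by one change only: methyl in place of hydrogen on a saturated chain carbon bound to a carbonyl carbon. Among the compounds with values here, no pair of measured compounds differs by this change, so nothing in the present numbers shows what it does in this assay; the only bearings are that compound 1 and compound 2, with different esters of the same core, sit within the scatter of each other.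

For compound 3 the step from compound 2 is expected to stay within the scatter, as a 1.1-fold higher number from compound 2 to compound 3 (0.04 log units; within the scatter). Compound 3 is thus estimated at 55 ug/mL in this assay, with a range from 25 ug/mL to 120 ug/mL, and it is not expected to report only a limit.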

Compound 3, half-maximal cytotoxic concentration: 40 ug/mL
Compound 3: middle estimate off by 1.4-fold (0.14 log units), on the high side; measured number inside the range.
By their numbers in this assay, from the lowest: compounds 3, 2 and 1 (each within the scatter of the next, the first and the last beyond it).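

Methyl in place of hydrogen on a saturated chain carbon bound to a carbonyl carbon, the change from acetoxy to propanoyloxy, now has a reading in this assay: a 1.3-fold lower number from compound 2 to compound 3 (0.10 log units; within the scatter). The two compounds are not separated by this test, so at this position the added methyl leaves no measurable mark on the read-out, which the earlier pair, differing in more than one place, could not show. This remains a single step on a single ester, and no measurement shown bears on why the number falls where it does.

Still open, on these data alone, is whether a longer chain at this place, such as butanoyloxy or a chain with a branch, would stay within the scatter of compound 2 or move beyond it, and whether an amine or a carboxylic acid on the same chain carbon would do the same. Also open, as far as these compounds go, is whether the same change, placed on the core of compound 1, would give a comparable step in this assay.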